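Swapping the chlorinated ring for a furan on an enone amide

The source may report more compounds than this note shows. Statements on the series, on what has been measured and on what is new or still open speak of the compounds shown alone.

Of the compounds shown here, two have been tested in a functional assay on the whole organism (strain albino) for inhibition, with Rattus norvegicus as the target, read by paw edema, with stated times of 30 min and 1 h, at a dose of 100 mg/kg by the oral route; a lower number here means less inhibition, a higher number more inhibition at the dose given (going by the name of the read-out). Compound 1, `Nc1ccc(C(=O)/C=C/c2ccco2)cc1`, carries a free amino group on one ring and a furan-2-yl group at the far end of its enone chain; in this assay compound 1 gives 33%. Compound 2, `CC(O[N+](=O)[O-])C(=O)Nc1ccc(C(=O)/C=C/c2ccc(Cl)cc2)cc1`, carries instead an amide bearing a nitrooxy group, and its enone chain ends in a 4-chlorophenyl group; in this assay compound 2 gives 45%. Compound 2 thus stands highest of the two numbers, and its gap to compound 1 lies beyond the usual scatter of repeated measurements.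

Compound 3, `CC(O[N+](=O)[O-])C(=O)Nc1ccc(C(=O)/C=C/c2ccco2)cc1`, keeps the amide of compound 2 and changes only the far ring: furan-2-yl in place of 4-chlorophenyl on a double-bonded chain carbon bound to a double-bonded chain carbon. Going by the values given here, no measured pair shows this exact change on its own. Because compound 1, which also ends in furan-2-yl, gives 33%, a modest decrease is expected, though it may not exceed the scatter. The step from compound 2 to compound 3 is therefore estimated at a number 5 percentage points lower from compound 2 to compound 3 (within the scatter). Compound 3 is expected to give about 40%, within a range from 28% to 52%.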

Compound 3, a percentage reported as inhibition, in the whole organism at one dose (the size of the read-out at that dose, not a potency): 41%
The estimate for compound 3 lay 1 percentage points below the measured number; the measured number falls inside the stated range.
By their numbers in this assay, from the lowest: compounds 1, 3 and 2 (each within the scatter of the next, the first and the last beyond it).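

In this assay, furan-2-yl in place of 4-chlorophenyl on a double-bonded chain carbon bound to a double-bonded chain carbon gives a number 4 percentage points lower from compound 2 to compound 3 (within the scatter), so this read-out does not tell these two rings apart at this place. Compound 3 also isolates the change at the other end of the molecule: a group of 8 heavy atoms (3 carbon, 1 nitrogen, 4 oxygen; no ring) in place of a hydrogen atom, on a nitrogen on an aromatic ring, gives a number 8 percentage points higher from compound 1 to compound 3 (within the scatter), so the amide bearing the nitrooxy group and the free amino group cannot be told apart here either. The gap beyond the scatter between compound 1 and compound 2 spans both changes, yet neither change alone reaches beyond the scatter.

The compounds shown leave open whether other groups at the far end of the chain, such as an unsubstituted phenyl or a thiophen-2-yl, or a plain acetyl on the nitrogen, would give a step beyond the scatter. No measurement at hand offers an explanation for the size of these steps.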